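A few compounds are considered here, and "the series" means these few. Any claim that something is new, unique, unknown or untested is made for them only; others in the source may bear on it.

Compound 1 `COc1ccc(/C=C/C(=O)c2cccc(-c3ccc(F)cc3)c2)cc1OC` gives 5550 nM in a functional assay on CNE-2 cells (Homo sapiens) for cytotoxicity, read by sulforhodamine B assay, with a stated time of 48 h; on this read-out lower numbers stand for stronger inhibition and higher numbers for weaker inhibition. Compound 3 `COc1cc(/C=C/C(=O)c2cccc(-c3cccc(F)c3)c2)ccc1O` gives 5690 nM. Compound 2 `COc1cc(/C=C/C(=O)c2ccc(N)c(-c3ccc(F)cc3)c2)cc(Br)c1O` gives 25500 nM.

On these three numbers compound 2 stands highest, beyond the scatter from both compound 3 and compound 1. Compound 4 `COc1cc(/C=C/C(=O)c2ccc(N)c(-c3ccc(F)cc3)c2)ccc1O` has not yet been tested. It differs from compound 2 in one place: hydrogen in place of bromo on an aromatic carbon. For the measured compounds named here, no pair of measured compounds differs in that place alone, so no step of this kind is known here; compound 3, which also carries a hydroxy and a methoxy group without a bromo, differs from compound 2 in further places as well. A modest step toward a lower number, possibly within the scatter, is expected for compound 4, a 1.7-fold lower number from compound 2 to compound 4 (0.23 log units; within the scatter). Compound 4 is estimated at 15000 nM, in the range 5000 nM to 40000 nM.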

Compound 4, half-maximal inhibitory concentration: 5750 nM
For compound 4 the middle estimate is 2.6-fold (0.42 log units) above the measured one; the measured number falls inside the stated range.
By their numbers in this assay, from the lowest: compounds 1, 3 and 4 (each within the scatter of the next); then compound 2.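

Hydrogen in place of bromo on an aromatic carbon, ortho to a hydroxy group, gives a 4.4-fold lower number from compound 2 to compound 4 (0.65 log units; beyond the scatter) in this assay. For the compounds shown here, this is the first single-place change seen here, and it shows that this position alone can move the number beyond the scatter. Nothing at hand gives a cause for this step. From the compounds shown here alone, the position rests on this one pair, so it remains open whether a chloro or a methyl group on this carbon would give a number nearer compound 2 or compound 4. Going by these compounds, it also remains open whether the step would be the same on a core without the amino group.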